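A few compounds are considered here, and "the series" means these few. Any claim that something is new, unique, unknown or untested is made for them only; others in the source may bear on it.

Measured in an ADME assay on BJ cells (Homo sapiens) for cytotoxicity, read by CellTiter-Glo and resazurin assay, with a stated time of 72 h; a higher number here means that more compound is needed for the effect, a lower number that less compound is needed:
- compound 1 `CC(C)N(Cc1cccc(OCCCCCC(=O)O)c1)C(=O)c1ccc(-c2cccc3ccccc23)cc1`: < 1.3 nM, a limit
- compound 2 `COc1cc(OC)cc(-c2ccc(C(=O)N(Cc3cccc(OCCCCCC(=O)O)c3)C(C)C)cc2)c1`: > 26000 nM, a limit
- compound 3 `COc1cc(F)cc(-c2ccc(C(=O)N(Cc3cccc(OCCCCCC(=O)O)c3)C(C)C)cc2)c1`: > 26000 nM, a limit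

Compound 3 has no number, only a limit: the limit of > 26000 nM in this assay, at which 2 of the 3 values shown sit.

Compound 4 `CC(C)N(Cc1cccc(OCCCCCC(=O)O)c1)C(=O)c1ccc(-c2cccc(Cl)c2)cc1` carries 3-chlorophenyl in place of 3-fluoro-5-methoxyphenyl on an aromatic carbon.

Two large steps bear on this change, an at least 20000-fold higher number from compound 1 to compound 2 (4.30 log units; beyond the scatter) and an at least 20000-fold higher number from compound 1 to compound 3 (4.30 log units; beyond the scatter), each taking away naphthalen-1-yl. Between the two remaining groups stands a step that the two limits leave unreadable from compound 2 to compound 3. Compound 4 also lacks naphthalen-1-yl, so no step beyond the scatter is expected in this assay, although a move to a lower number cannot be excluded. The expected change is an at least 1.3-fold lower number from compound 3 to compound 4 (0.11 log units; that floor lies within the scatter). For compound 4 the estimate is 20000 nM, with an expected range from 1500 nM to 30000 nM.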

Compound 4, half-maximal effective concentration: > 21900 nM
Compound 4 gave a limit, no number (the forecaster's own chance of this, stated with the estimate: 60%); at least 1.0-fold (0.03 log units) between middle value and limit.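

The step of an at least 16000-fold higher number from compound 1 to compound 4 (4.22 log units; beyond the scatter) shows that in this assay the large move away from compound 1 does not depend on a methoxy group, since the 3-chlorophenyl of compound 4 has none. At this position, 3-chlorophenyl therefore joins 3,5-dimethoxyphenyl and 3-fluoro-5-methoxyphenyl in standing far from naphthalen-1-yl. The steps among compound 2, compound 3 and compound 4 cannot be read, as each joins two limits.

As far as these compounds go, whether an unsubstituted phenyl or a naphthalen-2-yl group here would fall with compound 1 or with compound 4 stays open.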